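Extending methylamino to ethylamino on compound 2

A few compounds are considered here, and "the series" means these few. Any claim that something is new, unique, unknown or untested is made for them only; others in the source may bear on it.

Of the compounds shown here, two have numbers so far. In a functional assay on NCI-H460 cells (Homo sapiens) for cytotoxicity, read by MTT assay, with a stated time of 3 days (a lower number here means a stronger inhibitor, a higher number a weaker inhibitor), compound 1 `N#Cc1c(Cl)nc(SCc2nc3ccccc3[nH]2)nc1-c1ccccc1` gives 3.28 nM and compound 2 `CNc1nc(SCc2nc3ccccc3[nH]2)nc(-c2ccccc2)c1C#N` gives 3.2 nM with no real gap between them. Compound 2 therefore stands level with compound 1, within the scatter of repeated measurements. Compound 3 `CCNc1nc(SCc2nc3ccccc3[nH]2)nc(-c2ccccc2)c1C#N` has not been measured yet. It differs from compound 2 by one small change (methyl in place of hydrogen on a saturated chain carbon bound to a nitrogen on an aromatic ring), so methylamino becomes ethylamino. Going by the values given here, only one measured step bears on this, the change from chloro to methylamino on an aromatic carbon, and it amounted to a 1.0-fold lower number from compound 1 to compound 2 (0.01 log units; within the scatter) in size. Among the compounds with values here, that is a different change, and no measurement yet shows what lengthening this chain does. No step beyond the scatter is therefore expected in this assay in either direction. The estimate amounts to an expected 1.1-fold higher number from compound 2 to compound 3 (0.04 log units; within the scatter) in size. Compound 3 is expected at 3.5 nM with an estimated range of 1.3 nM to 10 nM for its measurement.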

Compound 3, half-maximal inhibitory concentration: 2.87 nM
Beside the measured number, compound 3's estimate is 1.2-fold (0.09 log units) above it, and the stated range covers the measured number.
By their numbers in this assay, from the lowest: compounds 3, 2 and 1 (each within the scatter of the next).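

In this assay, the methyl that turns methylamino into ethylamino gives a 1.1-fold lower number from compound 2 to compound 3 (0.05 log units; within the scatter), so the first step along this chain, on the saturated chain carbon bound to a nitrogen on an aromatic ring, stays within the scatter. Going straight from chloro to ethylamino on the aromatic carbon gives a 1.1-fold lower number from compound 1 to compound 3 (0.06 log units; within the scatter), which also stays within the scatter. This aromatic carbon has thus now carried chloro, methylamino and ethylamino with numbers that cannot be told apart, a level picture that rests on these three compounds alone and comes with no measurement that explains it.

The three compounds leave open how far this tolerance reaches: a longer chain such as propylamino, a branched one such as isopropylamino, or an amine with two alkyl groups such as dimethylamino could each stay level or move the number beyond the scatter. A carboxylic acid at the end of the chain, or a plain hydroxyl in place of the amine, is a larger departure whose effect in this assay these three values cannot predict.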